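Swapping an amino group for carbamoyl on the shared core

A few compounds are considered here, and "the series" means these few. Any claim that something is new, unique, unknown or untested is made for them only; others in the source may bear on it.

Of the compounds shown here, three with a shared core have been tested in a functional assay on the whole organism (strain ICR) for inhibition, with Mus musculus as the target, read by scintillation counting, with a stated time of 4 h, at a dose of 10 mg/kg by the oral route; a higher number here means more inhibition at the dose given (going by the name of the read-out), a lower number less inhibition. Compound 3 `Cn1c(-c2ccc(N)cc2Cl)nnc1C1(c2ccc(Cl)cc2)CCC1` gives 90%, the highest of the three numbers. Going by the values given here, compound 1 `CC(=O)Nc1ccc(-c2nnc(C3(c4ccc(Cl)cc4)CCC3)n2C)c(Cl)c1` carries acetyl on the ring nitrogen where compound 3 carries hydrogen, and compound 1 gives 79%; the step of a number 11 percentage points higher from compound 1 to compound 3 (beyond the scatter) is the only single-point change measured so far. Compound 2 `Cn1c(-c2ccc(C(N)=O)cc2C(N)=O)nnc1C1(c2ccc(Cl)cc2)CCC1` differs from compound 3 in two places rather than one, and compound 2 gives -11%.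

Compound 4 `Cn1c(-c2ccc(C(N)=O)cc2Cl)nnc1C1(c2ccc(Cl)cc2)CCC1` is the next compound, not yet measured. It differs from compound 3 as follows: carbamoyl in place of amino on an aromatic carbon. Among the compounds with values here, no measured step covers exactly this change. The nearest guide is compound 1, whose acetamide at the same position still gives 79%, so an amide-like group there keeps the number high, though the low number of compound 2 warns that a carbamoyl at this position might lower it. The step of a number 35 percentage points lower from compound 3 to compound 4 (beyond the scatter) is therefore expected to be a modest loss, with wide uncertainty. Compound 4 is estimated at 55%, in a range from 10% to 85%.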

Compound 4, a percentage reported as inhibition, in the whole organism at one dose (the size of the read-out at that dose, not a potency): 57%
Compound 4: middle estimate off by 2 percentage points, on the low side, within the range that was stated.
By their numbers in this assay, from the lowest: compound 2; then compound 4; then compound 1; then compound 3.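

In this assay this aromatic carbon, para to a large group, proves sensitive to which nitrogen group it carries: carbamoyl in place of amino gives a number 33 percentage points lower from compound 3 to compound 4 (beyond the scatter) and carbamoyl in place of acetamido gives a number 22 percentage points lower from compound 1 to compound 4 (beyond the scatter) on the same shared core. Both amino and acetamido therefore sit higher here than carbamoyl. Chloro in place of the second carbamoyl gives a number 68 percentage points higher from compound 2 to compound 4 (beyond the scatter) and shows that carbamoyl at this position does not by itself bring the number down to that of compound 2.

No measurement is at hand that explains these steps. From the compounds shown here alone, whether a carboxylic acid, a nitrile or a methylamino group at this position would stay nearer compound 3 or nearer compound 4 remains open, as does whether this order holds at other doses.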